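The source may hold more compounds than are shown below. What is called first, only, known or untested is meant among the compounds shown, and "the series" means these compounds.

Three compounds share one core and differ only in the chain attached to the sulfonamide nitrogen. Compound 1 `CCCNS(=O)(=O)c1ccc(Nc2ncc3c(n2)N(C2CCCC2)[C@H](CC)C(=O)N3C)cc1` carries a propyl chain there and in an assay for inhibition of serine/threonine-protein kinase PLK2 (Homo sapiens), read by FRET and Z'-LYTE, with a stated time of 1 h (on this read-out higher numbers stand for weaker inhibition and lower numbers for stronger inhibition), compound 1 gives 17.8 nM. Compound 2 `CCCCNS(=O)(=O)c1ccc(Nc2ncc3c(n2)N(C2CCCC2)[C@H](CC)C(=O)N3C)cc1` carries a butyl chain, and compound 2 gives 19.9 nM. Compound 3 `CC[C@@H]1C(=O)N(C)c2cnc(Nc3ccc(S(=O)(=O)NCC(C)C)cc3)nc2N1C1CCCC1` carries an isobutyl chain, and compound 3 gives 21.8 nM. The three numbers sit close together: a 1.1-fold higher number from compound 1 to compound 2 (0.05 log units; within the scatter), a 1.2-fold higher number from compound 1 to compound 3 (0.09 log units; within the scatter), and a 1.1-fold higher number from compound 2 to compound 3 (0.04 log units; within the scatter). Compound 3 therefore stands among three values that cannot be told apart, the steps reaching it from compound 1 and from compound 2 both within the scatter.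

Compound 4 `CC[C@@H]1C(=O)N(C)c2cnc(Nc3ccc(S(=O)(=O)NCCCO)cc3)nc2N1C1CCCC1` has not yet been measured. It differs from compound 3 by 2-hydroxyethyl in place of isopropyl on a saturated chain carbon bound to a sulfonamide nitrogen. Every step measured so far lengthens or branches this chain and leaves the number within the scatter, so the chain on the sulfonamide nitrogen has tolerated change. Among the compounds with values here, none of those steps, however, brings a hydrogen-bond donor or an oxygen into the chain, so there is no direct precedent for the new group. On that basis the expected step is a 1.1-fold higher number from compound 3 to compound 4 (0.04 log units; within the scatter), with a wider range than usual. Compound 4 is estimated at 24 nM, between 10 nM and 55 nM.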

Compound 4, half-maximal inhibitory concentration: 8.16 nM
The estimate for compound 4 lay 2.9-fold (0.47 log units) above the measured number, and the stated range ends above it.
By their numbers in this assay, from the lowest: compound 4; then compounds 1, 2 and 3 (each within the scatter of the next).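

Among the carbon chains on the sulfonamide nitrogen, propyl, butyl and isobutyl could not be told apart, yet in this assay the 3-hydroxypropyl chain of compound 4 gives a change beyond the scatter against each of them, with a 2.7-fold lower number from compound 3 to compound 4 (0.43 log units; beyond the scatter) and a 2.4-fold lower number from compound 2 to compound 4 (0.39 log units; beyond the scatter) and also a 2.2-fold lower number from compound 1 to compound 4 (0.34 log units; beyond the scatter) as the three steps. The comparison with butyl is the tightest, since hydroxy takes the place of methyl on a chain of the same length, and the comparison with propyl shows that adding hydroxy to the chain end goes the same way, so this position responds to a hydroxy group in a way it did not respond to added carbon, although each step is modest. Nothing available here explains why the number falls with this change.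

The compounds shown cannot separate the role of the oxygen from that of the hydroxy hydrogen, which a methoxy group at the chain end would help to do. They also leave open how a shorter or longer hydroxyalkyl chain would behave, and whether an amine or a carboxylic acid at the chain end would move the number in the same direction.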